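The compounds below may be only part of what the source reports. "The series", "measured", "known", "first", "only" and "open" are said of these compounds alone.

Measured in an ADME assay on the whole organism (plasma) for pharmacokinetics, with Rattus norvegicus as the target, at a dose of 5 mg/kg by the oral route (on this read-out lower numbers stand for lower exposure and higher numbers for higher exposure at the dose given), so far:
- compound 1 `CCC(CC)[C@@H]1C(=O)N[C@H](C2Cc3ccccc3C2)C(=O)N1[C@@H](C(=O)N1CCOCC1)c1ccc(C)nc1` gives 1380 ng.h/mL 
- compound 2 `CC[C@@H](C)[C@@H]1C(=O)N[C@H](C2Cc3ccccc3C2)C(=O)N1[C@@H](C(=O)N1CCOCC1)c1ccc(C)nc1` gives 1590 ng.h/mL 

Among the measured compounds shown here, compound 2 at 1590 ng.h/mL stands within the scatter of the only other measured compound, and the series offers a single step: a 1.2-fold higher number from compound 1 to compound 2 (0.06 log units; within the scatter). Compound 3 `CC[C@H](C)[C@@H]1C(=O)N[C@H](C2Cc3ccccc3C2)C(=O)N1[C@@H](C(=O)N1CCOCC1)c1ccc(C)nc1` is related to compound 2 by one change: the two compounds have the same atoms and bonds and differ only in configuration as drawn: 1 of 4 stereo elements differ; a stereocentre at a saturated chain carbon is drawn R in compound 2 and S in compound 3. No atoms leave or enter.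

The measured step exchanges pentan-3-yl for sec-butyl on a saturated ring carbon, whereas the new pair differs only in configuration as drawn. For the measured compounds named here, no measured pair differs in configuration alone, so the data hold no direct precedent. Going by the values given here, the measured step is the only guide to size, and it lies within the scatter. In this assay no step beyond the scatter is therefore expected, and no direction can be given. The estimated 1.1-fold lower number from compound 2 to compound 3 (0.03 log units; within the scatter) is expected to stay within the scatter, with a wide range kept for the missing precedent. For compound 3 the estimate is 1500 ng.h/mL with an expected range from 650 ng.h/mL to 3200 ng.h/mL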

Compound 3, area under the concentration-time curve: 1450 ng.h/mL
Compound 3: the middle estimate sits 1.0-fold (0.01 log units) above what was measured, and the stated range covers the measured number.
By their numbers in this assay, from the lowest: compounds 1, 3 and 2 (each within the scatter of the next).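

In this assay, the first pair differing in configuration alone shows that the stereocentre at this saturated chain carbon of the sec-butyl group can be drawn either way without a step beyond the scatter: a 1.1-fold lower number from compound 2 to compound 3 (0.04 log units; within the scatter). The exchange of pentan-3-yl for sec-butyl on the saturated ring carbon, read earlier with the R form only, now also stays within the scatter with the S form: a 1.1-fold higher number from compound 1 to compound 3 (0.02 log units; within the scatter). The step from compound 2 to compound 3 can be read as a test of this one stereocentre, because no atom or bond changes: the fact that compounds 2 and 3 differ only in the configuration as drawn

The compounds shown leave open whether inverting any of the remaining stereo elements would move the exposure beyond the scatter, and whether this holds at other doses or by other routes. They also leave open how the exposure would respond on the saturated ring carbon to a group other than these branched chains, such as a cyclopropyl ring, a hydroxyl-bearing chain or a carboxylic acid.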